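The source may report more compounds than this note shows. Statements on the series, on what has been measured and on what is new or still open speak of the compounds shown alone.

Working notes on the series. In an assay on isolated protein for inhibition of cytosolic endo-beta-N-acetylglucosaminidase (Homo sapiens), tested at 1000 uM (on this read-out higher numbers stand for more inhibition at the one concentration tested (going by the name of the read-out) and lower numbers for less inhibition), compound 1 `O=C(O)[C@H]1NCC=C[C@@H]1O` gives 60% and compound 2 `O=C(O)[C@H]1NCC=C[C@H]1O` gives 17%; the step of a number 43 percentage points lower from compound 1 to compound 2 (beyond the scatter) rests on (the fact that compounds 1 and 2 differ only in the configuration as drawn), so configuration alone moves the number a long way. Compound 3 `O=C(O)[C@H]1NC[C@H](O)[C@@H](O)[C@H]1O` gives 2.6% and stands lowest of the three measured, with compound 2 nearest and compound 1 furthest.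

Compound 4 `O=C(O)[C@@H]1NC[C@H](O)[C@@H](O)[C@H]1O` is the next point: the two compounds have the same atoms and bonds and differ only in configuration as drawn: 1 of 4 stereo elements differ; a stereocentre at a saturated ring carbon is drawn S in compound 3 and R in compound 4. Among the measured compounds shown here, the only comparable step is the inversion from compound 1 to compound 2, which was large; it concerned a different stereocentre, so its direction cannot simply be carried over. Compound 3 already sits near the floor, so the expected step of a number 9.4 percentage points higher from compound 3 to compound 4 (within the scatter) is upward if anything, with wide uncertainty. Compound 4 is estimated at 12%, between 0% and 50%.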

Compound 4, a percentage reported as inhibition, at one concentration (the size of the read-out at that concentration, not a potency): 42%
Beside the measured number, compound 4's estimate is 30 percentage points below it; measured number inside the range.
By their numbers in this assay, from the lowest: compound 3; then compound 2; then compound 4; then compound 1.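

In this assay, inverting this stereocentre at a saturated ring carbon from drawn S to drawn R gives a number 39.4 percentage points higher from compound 3 to compound 4 (beyond the scatter), whereas the same drawn change at another stereocentre gave a number 43 percentage points lower from compound 1 to compound 2 (beyond the scatter). Configuration alone therefore moves the number a long way in both pairs, with the direction differing between these two stereocentres. Nothing enters or leaves in this step, so it is a pure inversion: the fact that compounds 3 and 4 differ only in the configuration as drawn.

Going by these compounds, the effect of inverting the other stereocentres of compound 4 remains open. So does whether a methyl ester or a primary amide in place of the carboxylic acid would preserve its inhibition.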